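A few compounds are considered here, and "the series" means these few. Any claim that something is new, unique, unknown or untested is made for them only; others in the source may bear on it.

Measured so far in an ADME assay on Vero cells (Chlorocebus sabaeus) for cytotoxicity, read by MTT assay, with a stated time of 48 h; on this read-out higher numbers stand for weaker inhibition and lower numbers for stronger inhibition:

- compound 1 `CN(Cc1ccc2c(c1)OCCO2)c1nc(=O)c2cc(C(F)(F)F)cc([N+](=O)[O-])c2o1`: 9.27 ug/mL
- compound 2 `O=c1cc(NCc2ccc3c(c2)OCCO3)sc2c([N+](=O)[O-])cc(C(F)(F)F)cc12`: > 64 ug/mL, which is a limit of the assay and not a number
- compound 3 `CC1COC2(CCN(c3cc(=O)c4cc(C(F)(F)F)cc([N+](=O)[O-])c4s3)CC2)O1`: > 64 ug/mL, which is a limit of the assay and not a number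

Going by the values given here, compound 1 stands alone as the only number in this assay; the other two values sit at the limit of > 64 ug/mL in this assay, at which 2 of the 3 values shown sit. Among the compounds with values here, no pair of measured compounds differs in one place, so no step between measured compounds can be worked out, and the series gives no direction to lean on.

Compound 4 `CN(Cc1ccccc1)c1nc(=O)c2cc(C(F)(F)F)cc([N+](=O)[O-])c2o1` has not yet been measured in this assay. It differs from compound 1 in one place: phenyl in place of 2,3-dihydro-1,4-benzodioxin-6-yl on a saturated chain carbon bound to a nitrogen on an aromatic ring. The shared core of compound 1 is otherwise kept unchanged.

Within the data shown here, with no measured step to draw on, the step of a 1.3-fold higher number from compound 1 to compound 4 (0.11 log units; within the scatter) is expected to stay within the usual scatter, with no clear direction. For compound 4 the expected value in this assay is estimated at 12 ug/mL, with a range from 4 ug/mL to 40 ug/mL.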

Compound 4, half-maximal inhibitory concentration: 3.84 ug/mL
The estimate for compound 4 lay 3.1-fold (0.49 log units) above the measured number; the measured number lies below the stated range.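

On the saturated chain carbon bound to a nitrogen on an aromatic ring, phenyl in place of 2,3-dihydro-1,4-benzodioxin-6-yl gives, in this assay, a 2.4-fold lower number from compound 1 to compound 4 (0.38 log units; beyond the scatter). Going by these compounds alone, this is the first readable change, and it shows that this place alters the number while the shared core stays unchanged. The 2,3-dihydro-1,4-benzodioxin-6-yl group is not required for cytotoxicity in this core, since the plain phenyl of compound 4 gives the stronger inhibition.

Going by these compounds, whether a chlorine on the phenyl, a pyridine in its place or a longer chain carrying it would move the number further remains open. This single step gives no pattern, and compound 2 and compound 3 cannot be compared with it, as each differs from compound 1 in more than one place: the limit of > 64 ug/mL in this assay, at which 2 of the 4 values shown sit.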